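Compound 4 and One More Chloro

This account rests on a few compounds, and the source may have more. Where it says the series, first, only, none or still open, it means among the compounds named here.

In a functional assay on MCF7 cells (Homo sapiens) for antiproliferative activity, read by MTT assay, with a stated time of 48 h (a higher number here means a weaker inhibitor, a lower number a stronger inhibitor), compound 1 (`O=C(NS(=O)(=O)c1ccccc1)c1cccnc1`) gives 14400 nM and compound 3 (`O=C(NS(=O)(=O)c1ccccc1)c1ccc(Cl)nc1`) gives 14100 nM. These two values lie within the scatter of each other, while compound 2 (`O=C(NS(=O)(=O)c1ccc(Cl)cc1)c1cncc(Br)c1`) gives 70 nM, a far lower number than compound 3 shows. Compound 4 (`O=C(NS(=O)(=O)c1ccc(Cl)cc1)c1ccc(Cl)nc1`) differs from compound 3 in one place: chloro in place of hydrogen on an aromatic carbon. This is chloro in place of hydrogen on an aromatic carbon of a six-membered aromatic ring of carbon only, para to a large group.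

Going by the values given here, the only measured single-place step is a 1.0-fold lower number from compound 1 to compound 3 (0.01 log units; within the scatter). It is the same kind of exchange and stays within the scatter, but it lies on a different ring. Compound 2 carries the new chloro, yet it also differs from compound 3 elsewhere, so the data do not separate the two changes. A lower number is therefore expected, though probably not the full gap to compound 2, and the uncertainty is wide. The expected step is a 20-fold lower number from compound 3 to compound 4 (1.30 log units; beyond the scatter). Compound 4 is estimated at 700 nM, with an expected range of 70 nM to 7000 nM.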

Compound 4, half-maximal inhibitory concentration: 8070 nM
For compound 4 the middle estimate is 12-fold (1.06 log units) below the measured one, outside the stated range (above it).
By their numbers in this assay, from the lowest: compound 2; then compounds 4, 3 and 1 (each within the scatter of the next).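

In this assay the exchange of hydrogen for chloro on an aromatic carbon of a six-membered aromatic ring of carbon only, para to a large group, gives a 1.7-fold lower number from compound 3 to compound 4 (0.24 log units; within the scatter) and so stays within the scatter, as the chloro exchange on the other ring does with a 1.0-fold lower number from compound 1 to compound 3 (0.01 log units; within the scatter). Going by these compounds alone, this is the first reading of that chloro by itself, which compound 2 could not give, as it differs from compound 3 in more than this one place. Nothing given here explains why the step is so small.

On these data alone, it remains open how much of the low number of compound 2 belongs to its bromo, and whether that bromo needs the chloro on the carbon ring. Whether an amine or a methoxy group in this same place would give a step beyond the scatter also stays unanswered.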